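The source may report more compounds than this note shows. Statements on the series, on what has been measured and on what is new or still open speak of the compounds shown alone.

Measured compounds:
compound 1 `CC1=C(/C=C/C(=O)/C=C/c2ccc(F)cc2)C(C)(C)CCC1`, 8200 nM
compound 2 `CC1=C(/C=C/C(=O)/C=C/c2ccccc2[N+](=O)[O-])C(C)(C)CCC1`, 9500 nM

Of the compounds shown here, two sharing one dienone core have been tested in a functional assay on PC-3 cells (Homo sapiens) for cytotoxicity, read by sulforhodamine B assay, with a stated time of 48 h; on this read-out lower numbers stand for stronger inhibition and higher numbers for weaker inhibition. Compound 1 gives 8200 nM, and compound 2 gives 9500 nM; the two values lie within the usual scatter of each other, so neither compound is separated from the other on this assay.

Compound 3 `CC1=C(/C=C/C(=O)/C=C/c2ccccc2Br)C(C)(C)CCC1` is the next step. Compared with compound 2, the change is bromo in place of nitro on an aromatic carbon, placed on an aromatic carbon of a six-membered aromatic ring of carbon only, ortho to a large group. Within the data shown here, no measured pair shows what such a swap does here, so the expectation rests only on the two values above, which sit close together. Compound 3 is therefore expected to stay in the same region, with a step of a 1.4-fold lower number from compound 2 to compound 3 (0.13 log units; within the scatter) that does not go beyond the scatter. The estimate for compound 3 is 7000 nM, ranging from 2500 nM to 20000 nM.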

Compound 3, half-maximal inhibitory concentration: 11400 nM
The estimate for compound 3 lay 1.6-fold (0.21 log units) below the measured number, within the range that was stated.
By their numbers in this assay, from the lowest: compounds 1, 2 and 3 (each within the scatter of the next).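

Among these compounds, on this assay the swap of bromo in place of nitro on an aromatic carbon, ortho to a large group, gives a 1.2-fold higher number from compound 2 to compound 3 (0.08 log units; within the scatter) and is the first measured step at this position. The position thus holds either nitro, with three heavy atoms and two hydrogen-bond acceptors, or bromo, with one heavy atom and no acceptors, without separating the two compounds. Likewise, 2-bromophenyl in place of 4-fluorophenyl gives a 1.4-fold higher number from compound 1 to compound 3 (0.14 log units; within the scatter) and does not separate that pair either.

Going by these compounds, whether an amine or a carboxylic acid at this position would give a step beyond the scatter stays open. So does the effect of a change elsewhere on the shared core, such as a longer chain in place of a methyl group. No measurement at hand bears on this result.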